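The source may hold more compounds than are shown below. What is called first, only, known or untested is meant among the compounds shown, and "the series" means these compounds.

Working notes on the series.

Compound 1 `CCN(CC)c1ccc(NC(=O)c2cn(Cc3c(F)cccc3F)c3ccc(=O)[nH]c3c2=O)cc1` and compound 2 `Nc1ccc(NC(=O)c2cn(Cc3c(F)cccc3F)c3ccc(=O)[nH]c3c2=O)cc1` share one core and differ only at the aryl amine: in an in vitro assay on Sf21 cells for inhibition of high affinity 3',5'-cyclic-AMP phosphodiesterase 7A (Homo sapiens), read by scintillation proximity assay, with a stated time of 30 min (on this read-out higher numbers stand for weaker inhibition and lower numbers for stronger inhibition), compound 1 gives 46 nM, while compound 2 gives 104 nM. For the measured compounds named here, the step of a 2.3-fold higher number from compound 1 to compound 2 (0.35 log units; beyond the scatter) is the only measured change so far, and compound 2 therefore stands with the higher of the two numbers.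

Compound 3 `CC(=O)Nc1ccc(NC(=O)c2cn(Cc3c(F)cccc3F)c3ccc(=O)[nH]c3c2=O)cc1` takes compound 2 one step further: acetyl in place of hydrogen on a nitrogen on an aromatic ring, that is amino to acetamido, or 4-aminophenyl to 4-acetamidophenyl. Going by the values given here, no measured step bears directly on acetylation of this nitrogen; the one known step shows that a change at this position moved this assay modestly, so a step of similar or smaller size is expected here, with no strong reason for a direction.

Compound 3 is therefore expected to give about 130 nM in this assay, estimated between 45 nM and 400 nM, a step of a 1.3-fold higher number from compound 2 to compound 3 (0.10 log units; within the scatter) from compound 2.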

Compound 3, half-maximal inhibitory concentration: 24 nM
The estimate for compound 3 lay 5.4-fold (0.73 log units) above the measured number; the whole stated range lies above it.
By their numbers in this assay, from the lowest: compounds 3 and 1 (each within the scatter of the next); then compound 2.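

In this assay, for the compounds shown here, acetyl in place of hydrogen on the nitrogen gives a 4.3-fold lower number from compound 2 to compound 3 (0.64 log units; beyond the scatter) and shows that this position can also respond to a change in the direction of lower numbers, which the one earlier step did not show. Acetamido in place of diethylamino gives a 1.9-fold lower number from compound 1 to compound 3 (0.28 log units; within the scatter) and so leaves these two groups unseparated, with the amino group of compound 2 alone giving the highest number of the three. The data offer no measured explanation for either step.

On these data alone, it remains open whether a longer acyl chain, such as propionyl or benzoyl, or a methanesulfonyl group on this nitrogen would behave as acetyl does. As far as these compounds go, it is also open whether the step from amino to acetamido would keep its size with another group in place of the 2,6-difluorobenzyl group on the shared core.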